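The source may hold more compounds than are shown below. What is called first, only, known or untested is meant among the compounds shown, and "the series" means these compounds.

Measured in an assay on FRT-Jurkat cells for inhibition of nuclear factor NF-kappa-B complex (Homo sapiens), read by flow cytometry, with a stated time of 24 h, tested at 10 uM; on this read-out higher numbers stand for more inhibition at the one concentration tested (going by the name of the read-out) and lower numbers for less inhibition:
- compound 1 `O=C1CCC(N2C(=O)c3ccc(Nc4ccccn4)cc3C2=O)C(=O)N1`: 9%
- compound 2 `O=C1CCC(N2C(=O)c3cccc(Nc4ccccn4)c3C2=O)C(=O)N1`: 1%
- compound 3 `COc1ccc(Nc2cccc3c2C(=O)N(C2CCC(=O)NC2=O)C3=O)cc1`: 13%

Compound 1 gives the second highest of the three numbers; its gaps to compound 3 and to compound 2 both lie within the scatter, so no order among the three can be stated. Compound 4 `COc1ccc(Nc2ccc3c(c2)C(=O)N(C2CCC(=O)NC2=O)C3=O)cc1` is not yet measured. It differs from compound 1 in one place: 4-methoxyphenyl in place of pyridin-2-yl on a nitrogen on an aromatic ring. Within the data shown here, one measured step bears on this change, on the other arrangement of the shared core: a number 12 percentage points higher from compound 2 to compound 3 (beyond the scatter). Carrying that step over, a modest rise is expected for compound 4 in this assay, with the step of a number 11 percentage points higher from compound 1 to compound 4 (beyond the scatter). Compound 4 is estimated at 20%, within a range from 8% to 34%.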

Compound 4, a percentage reported as inhibition, at one concentration (the size of the read-out at that concentration, not a potency): 29%
Estimate against measurement, compound 4: 9 percentage points below; measured number inside the range.
By their numbers in this assay, from the lowest: compounds 2, 1 and 3 (each within the scatter of the next, the first and the last beyond it); then compound 4.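

In this assay, the change to 4-methoxyphenyl from pyridin-2-yl now also reads beyond the scatter on the core of compound 1, with a number 20 percentage points higher from compound 1 to compound 4 (beyond the scatter). The change therefore points the same way on both arrangements of the shared core, and the two steps do not separate in size: the same change on two cores in this assay, a number 12 percentage points higher (beyond the scatter) from compound 2 to compound 3 and a number 20 percentage points higher (beyond the scatter) from compound 1 to compound 4, 8 percentage points apart, within the scatter of two such steps.

Still open, going by these compounds, is whether the rise follows the methoxy group or the carbon-only ring; a plain phenyl, or a phenyl carrying an amine or a carboxylic acid, on the same nitrogen would bear on this. On these data alone, with one concentration per compound, potency also remains open.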